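A Methyl-Bearing Amide Step on L02 Cells

The compounds below may be only part of what the source reports. "The series", "measured", "known", "first", "only" and "open" are said of these compounds alone.

Compound 1 `COc1ccc(CNC(=O)/C=C/c2coc3cc(O)ccc3c2=O)cc1`: > 200000 nM (a limit)
Compound 2 `Cc1ccccc1NC(=O)/C=C/c1coc2cc(O)ccc2c1=O`: > 200000 nM (a limit)

Both compounds were tested in a functional assay on L02 cells (Homo sapiens) for inhibition, read by MTT assay, with a stated time of 48 h; on this read-out lower numbers stand for stronger inhibition and higher numbers for weaker inhibition. There, compound 2 gives > 200000 nM, which is a limit and not a number. It therefore has no exact place on the scale, and the measured set offers only this: the limit of > 200000 nM in this assay, at which 2 of the 2 values shown sit.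

The next compound is compound 3 `Cc1ccc(CNC(=O)/C=C/c2coc3cc(O)ccc3c2=O)cc1`, which has 4-methylbenzyl in place of 2-methylphenyl on an amide-type nitrogen. Among the measured compounds shown here, no step between measured compounds is available as a guide in this assay. The expectation rests on the limit of compound 2 at > 200000 nM, and no change beyond the scatter is expected in either direction. The expected step is a number no higher from compound 2 to compound 3 (the limit leaves the size open). A further limit would be the most likely report. For compound 3 the estimated value is 200000 nM, with an expected range from 100000 nM to 400000 nM.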

Compound 3, half-maximal inhibitory concentration: > 200000 nM
Compound 3 was reported as a limit; the forecaster's own chance of this, stated with the estimate: 80%; the middle value lies on the limit itself.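

In this assay compound 3 gives > 200000 nM, a limit and not a number. The steps from compound 1 and from compound 2 to compound 3 cannot be read. The compounds shown leave open how these three compounds actually compare on these cells.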